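The source may hold more compounds than are shown below. What is called first, only, known or untested is meant among the compounds shown, and "the series" means these compounds.

Measured compounds in the series:
- compound 1, `Cc1n[nH]c2ccc(-c3nc4cnc(N5CCN(C)CC5)cn4c3Nc3ccccc3Cl)cc12`: "not determined" (no result reported) in a functional assay on MV4-11 cells (Homo sapiens) for inhibition, with a stated time of 120 h; on this read-out higher numbers stand for weaker inhibition and lower numbers for stronger inhibition
- compound 2, `Cc1n[nH]c2ccc(-c3nc4cnc(N5CCN(C)CC5)cn4c3Nc3ccc(Br)cc3)cc12`: 2600 nM
- compound 3, `Cc1n[nH]c2ccc(-c3nc4cnc(N5CCN(C)CC5)cn4c3Nc3ccccc3)cc12`: "not determined" (no result reported) in this assay

Compound 3 has no number in this assay; the same holds for compound 1, so the only anchor in the set is compound 2, which in this assay gives 2600 nM. Going by the values given here, no step between two measured compounds can be drawn, and nothing in the data shows how the shared core responds to substitution on the phenyl ring attached to the nitrogen.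

Compound 4, `Cc1n[nH]c2ccc(-c3nc4cnc(N5CCN(C)CC5)cn4c3Nc3ccc(Cl)cc3Cl)cc12`, differs from compound 3 in one place: 2,4-dichlorophenyl in place of phenyl on a nitrogen on an aromatic ring. With compound 3 unmeasured, the size of this step in this assay cannot be compared to any measured pair. Among the compounds with values here, the expectation is that compound 4 lands near the only available reading, that of compound 2, and that any deviation from it stays within or only just beyond the scatter, with no firm direction assignable. In this assay compound 4 is therefore expected to give about 2000 nM, with a plausible range from 500 nM to 8000 nM.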

Compound 4, half-maximal inhibitory concentration: 4720 nM
Estimate against measurement, compound 4: 2.4-fold (0.37 log units) below; measured number inside the range.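

In this assay, going by these compounds alone, exchanging 4-bromophenyl for 2,4-dichlorophenyl on the nitrogen on an aromatic ring gives a 1.8-fold higher number from compound 2 to compound 4 (0.26 log units; within the scatter), the first step that can be read at this position. The two groups therefore cannot be told apart in this assay: a ring carrying one bromine and a ring carrying two chlorines give readings within the usual scatter of each other, so this pair shows no dependence on which of these two halogen patterns is present. The steps that link compound 4 to compound 1 and to compound 3 cannot be read, as neither of those two compounds has a number, so the effect of adding halogen to the plain phenyl ring remains undefined.

Still open, as far as these compounds go, is how this position responds to groups other than halogens on the phenyl ring, such as a methoxy group, a carboxylic acid or a basic amine, and to replacement of the phenyl ring by a pyridine ring. No measurement in hand bears on why these two compounds read alike.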